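From phenoxymethyl to cyclohexyl on compound 1

A few compounds are considered here, and "the series" means these few. Any claim that something is new, unique, unknown or untested is made for them only; others in the source may bear on it.

Measured in a functional assay on HeLa cells (Homo sapiens) for cytotoxicity, read by MTT assay, with a stated time of 72 h; a higher number here means a weaker inhibitor, a lower number a stronger inhibitor:
- compound 1 `O=C(COc1ccccc1)Nc1nnc(-c2cccc(O)c2O)s1` gives 117000 nM
- compound 2 `O=C(Nc1nnc(-c2ccc(O)c(O)c2)s1)c1ccc(Cl)cc1` gives 47300 nM

Compound 1 holds the higher of these two numbers, which makes it the weaker inhibitor, and its gap to compound 2 lies beyond the usual scatter. These two compounds differ in more than one place, so their gap cannot be tied to any single change.

Compound 3 `O=C(Nc1nnc(-c2cccc(O)c2O)s1)C1CCCCC1` has not been measured yet. It keeps the core of compound 1 but carries cyclohexyl in place of phenoxymethyl on a carbonyl carbon in its structure. Going by the values given here, no measured pair shows what this swap does, so the forecast is loose. Among the compounds with values here, with compound 1 at 117000 nM as the higher of only two numbers, a large further rise seems unlikely. Expected in this assay is a step of a 1.4-fold lower number from compound 1 to compound 3 (0.14 log units; within the scatter) that stays within the scatter, leaning slightly toward a lower number. Compound 3 is estimated at 85000 nM with an expected range from 35000 nM to 200000 nM around it.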

Compound 3, half-maximal inhibitory concentration: 91600 nM
Compound 3: middle estimate off by 1.1-fold (0.03 log units), on the low side; low and high end bracket the measured number.
By their numbers in this assay, from the lowest: compounds 2, 3 and 1 (each within the scatter of the next, the first and the last beyond it).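

In this assay, putting cyclohexyl in place of phenoxymethyl on a carbonyl carbon gives a 1.3-fold lower number from compound 1 to compound 3 (0.11 log units; within the scatter), so compound 1 and compound 3 cannot be told apart. At this position, then, the aromatic ring and the oxygen of phenoxymethyl can both leave, and a non-aromatic carbon ring can enter, without a change that stands out from the scatter. No available measurement offers an explanation for this result.

From the compounds shown here alone, only these two groups have been compared directly here, so it remains open whether a group of another kind on this carbonyl carbon, such as an amine or a carboxylic acid, would shift the number. Compound 2 differs from both in more than one place. Its gap to compound 1 cannot be tied to any single change.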